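The compounds below may be only part of what the source reports. "The series", "measured", "known", "first", "only" and "open" are said of these compounds alone.

In an assay on mitochondria from L6 cells (Rattus norvegicus) for activation, with a stated time of 90 min (a lower number here means that less compound is needed, a higher number that more compound is needed for the effect), three compounds have been measured so far:
compound 1, `Fc1ccc(Nc2nc3nonc3nc2Nc2ccccc2F)cc1`, gives 2300 nM;
compound 2, `Fc1ccc(Nc2nc3nonc3nc2Nc2ccccc2F)c(F)c1`, gives 300 nM;
compound 3, `COc1cccc(Nc2nc3nonc3nc2Nc2ccccc2F)c1`, gives 830 nM.

Among these, compound 3 stands second highest. Its nearest neighbour is compound 2, reached by a 2.8-fold higher number from compound 2 to compound 3 (0.44 log units; beyond the scatter); its furthest is compound 1, as shown by a 2.8-fold lower number from compound 1 to compound 3 (0.44 log units; beyond the scatter). The next compound is compound 4, `Fc1ccccc1Nc1nc2nonc2nc1Nc1ccccn1`. The change from compound 3 is pyridin-2-yl in place of 3-methoxyphenyl on a nitrogen on an aromatic ring. For the measured compounds named here, two measured steps touch the same place: the group on that nitrogen was swapped in a 2.8-fold lower number from compound 1 to compound 3 (0.44 log units; beyond the scatter) and in a 2.8-fold higher number from compound 2 to compound 3 (0.44 log units; beyond the scatter), both modest and in opposite directions, so swapping this group has so far moved the number only moderately. The step of a 7.7-fold lower number from compound 1 to compound 2 (0.88 log units; beyond the scatter) concerns a fluoro on that same ring and is larger. Going by the values given here, no measured step puts pyridin-2-yl on this nitrogen, so the direction for compound 4 is uncertain. A modest step is therefore expected, giving a 1.3-fold higher number from compound 3 to compound 4 (0.12 log units; within the scatter) as the estimate. Compound 4 is expected to give about 1100 nM in this assay, within 300 nM to 4000 nM.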

Compound 4, half-maximal effective concentration: 9000 nM
Compound 4: the middle estimate sits 8.2-fold (0.91 log units) below what was measured; measured number outside the range, above it.
By their numbers in this assay, from the lowest: compound 2; then compound 3; then compound 1; then compound 4.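

Swapping the group on this nitrogen had so far moved the number only moderately, but in this assay the same position now also gives large steps with pyridin-2-yl (an 11-fold higher number from compound 3 to compound 4 (1.04 log units; beyond the scatter)) and (a 30-fold higher number from compound 2 to compound 4 (1.48 log units; beyond the scatter)), while the step from the highest earlier number stays modest (a 3.9-fold higher number from compound 1 to compound 4 (0.59 log units; beyond the scatter)). All three steps point the same way, so among these four compounds 3-methoxyphenyl, 4-fluorophenyl and 2,4-difluorophenyl on this nitrogen each give a lower number than pyridin-2-yl, by an amount that depends on the group replaced. Nothing available gives a measured reason for this rise.

Still open, on these data alone, is whether pyridin-3-yl or pyridin-4-yl on this nitrogen would match pyridin-2-yl or give a lower number. Also open, as far as these compounds go, is whether a fluoro or methoxy group on the pyridin-2-yl ring would bring the number back down.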